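The source may report more compounds than this note shows. Statements on the series, on what has been measured and on what is new or still open speak of the compounds shown alone.

In an ADME assay on Vero cells (Chlorocebus sabaeus) for cytotoxicity, read by MTT assay, with a stated time of 72 h (on this read-out higher numbers stand for lower toxicity in this test and lower numbers for higher toxicity in this test), compound 1 `COC(=O)c1cc(-c2cccc(NC(=O)c3ccc(/C=C/C(=O)c4cc(F)ccc4F)cc3)c2)on1` gives only a limit, > 40 ug/mL. Compound 3 `CCOC(=O)c1cc(-c2cccc(NC(=O)c3ccc(/C=C/C(=O)c4ccc(Cl)cc4)cc3)c2)on1` likewise gives only a limit, > 80 ug/mL. Compound 2 `COC(=O)c1cc(-c2cccc(NC(=O)c3ccc(/C=C/C(=O)c4ccc(CC(C)C)cc4)cc3)c2)on1` also gives only a limit, > 10 ug/mL, so where it stands among the three measured compounds cannot be ranked; all three values sit at limits (the limit of > 10 ug/mL in this assay, at which 1 of the 3 values shown sits, (the limit of > 40 ug/mL in this assay, at which 1 of the 3 values shown sits), (the limit of > 80 ug/mL in this assay, at which 1 of the 3 values shown sits)). Compound 4 `COC(=O)c1cc(-c2cccc(NC(=O)c3ccc(/C=C/C(=O)c4ccccc4Br)cc3)c2)on1` carries 2-bromophenyl in place of 4-isobutylphenyl on a carbonyl carbon. Among the measured compounds shown here, the one measured step at the same carbonyl carbon, a step that the two limits leave unreadable from compound 1 to compound 2, has limits at both ends and offers neither a size nor a direction to lean on. Compound 4 is therefore expected to move little beyond the scatter, a step that the limit leaves unreadable from compound 2 to compound 4 in this assay. Compound 4 is estimated at 40 ug/mL, within 15 ug/mL to 100 ug/mL.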

Compound 4, half-maximal cytotoxic concentration: > 40 ug/mL
Compound 4 gave a limit, no number (the forecaster's own chance of this, stated with the estimate: 70%); the middle value lies on the limit itself.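

Compound 1, compound 2 and compound 4 all give only limits, so neither step to compound 4 can be read. From the compounds shown here alone, whether changing the group on the carbonyl carbon shifts this read-out at all, and in which direction, stays open.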